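Hydroxy to methoxy on compound 1: expected effect

The compounds below may be only part of what the source reports. "The series", "measured", "known", "first", "only" and "open" are said of these compounds alone.

Measured so far:
- compound 1 `COc1ccc(/C=C/C(=O)c2ccc(N)c(-c3ccc(F)cc3)c2)cc1O` gives "not determined" (no result reported)
- compound 2 `COc1ccc(/C=C/C(=O)c2cccc(Br)c2)cc1` gives "not determined" (no result reported)
- compound 3 `COc1ccc(/C=C/C(=O)c2cccc(-c3cccc(F)c3)c2)cc1` gives 3080 nM

In a functional assay on MCF7 cells (Homo sapiens) for cytotoxicity, read by sulforhodamine B assay, with a stated time of 48 h (on this read-out lower numbers stand for stronger inhibition and higher numbers for weaker inhibition), compound 1 has no single number, and its entry reads "not determined" (no result reported). Compound 2 is in the same position with "not determined" (no result reported). For the measured compounds named here, compound 3 is the only member of the series with a numeric reading, so compound 1 cannot be ranked against anything.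

Compound 4 `COc1ccc(/C=C/C(=O)c2ccc(N)c(-c3ccc(F)cc3)c2)cc1OC` is still unmeasured. The structural change is methyl in place of hydrogen on an oxygen on an aromatic ring, or hydroxy to methoxy. Going by the values given here, no measured pair shows this change, and compound 1 offers no starting value, so the size of the step cannot be read from the data. On that footing, no step beyond the usual scatter is expected in this assay, and neither direction is favoured. Among the compounds with values here, the only numeric anchor is compound 3 at 3080 nM, and it differs from compound 4 in more than this one place, so the range has to stay wide. For compound 4 the estimated value is 3000 nM, with an expected range from 500 nM to 15000 nM.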

Compound 4, half-maximal inhibitory concentration: 15000 nM
Beside the measured number, compound 4's estimate is 5.0-fold (0.70 log units) below it, and the stated range covers the measured number.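

In this assay, for the compounds shown here, compound 4 gives 15000 nM while compound 1 reads "not determined" (no result reported) and so no step from hydroxy to methoxy can be read from this pair. The compounds shown leave open how methyl in place of hydrogen on that oxygen shifts the reading. No evidence bearing on this result is available.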